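The source may hold more compounds than are shown below. What is called first, only, known or untested is meant among the compounds shown, and "the series" means these compounds.

Measured compounds:
- compound 1, `CN1CCN(c2nc(Nc3ccc(C#N)c(C(F)(F)F)c3)nc(Oc3ccnc4ccccc34)n2)CC1`, gives 51200 nM in a functional assay on DU-145 cells (Homo sapiens) for cytotoxicity, read by sulforhodamine B assay, with a stated time of 48 h; on this read-out higher numbers stand for weaker inhibition of growth and lower numbers for stronger inhibition of growth
- compound 2, `N#Cc1ccc(Nc2nc(Oc3ccnc4ccccc34)nc(N3CCN(c4ncccn4)CC3)n2)cc1C(F)(F)F`, gives 85200 nM in this assay

Both values come from this assay. Compound 1 stands at the lower of the two numbers shown, but the gap to compound 2 is a 1.7-fold higher number from compound 1 to compound 2 (0.22 log units; within the scatter), so the two compounds cannot be told apart on these data.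

Compound 3, `N#Cc1ccc(Nc2nc(Oc3ccnc4ccccc34)nc(N3CCN(c4ccccc4)CC3)n2)cc1C(F)(F)F`, has not yet been measured. It differs from compound 1 at one place: phenyl in place of methyl on an amine nitrogen in a ring. Seen one bond further out, the change reads 4-methylpiperazin-1-yl to 4-phenylpiperazin-1-yl.

Going by the values given here, only one measured step bears on this change: the step from compound 1 to compound 2, where a pyrimidin-2-yl replaced the same methyl on the same ring nitrogen and gave a 1.7-fold higher number from compound 1 to compound 2 (0.22 log units; within the scatter). A phenyl is another six-membered aromatic ring in that position, so no step beyond the scatter is expected in this assay, with at most a slight drift toward a higher number.

Compound 3 is therefore estimated at 60000 nM, within a range of 25000 nM to 150000 nM, which means an expected step of a 1.2-fold higher number from compound 1 to compound 3 (0.07 log units; within the scatter).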

Compound 3, concentration for 50% growth inhibition: > 100000 nM
Compound 3: no number, only a limit; the forecaster's own chance of this, stated with the estimate: 15%; middle value at least 1.6-fold (0.22 log units) away from the limit.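

In this assay compound 3 gives > 100000 nM, which is a limit of the assay and not a number. The steps to it are therefore floors, an at least 1.9-fold higher number from compound 1 to compound 3 (0.29 log units; that floor lies within the scatter) and an at least 1.1-fold higher number from compound 2 to compound 3 (0.06 log units; that floor lies within the scatter), and the true size of either step could be larger than what is printed, so phenyl on this amine nitrogen cannot yet be set apart from methyl or pyrimidin-2-yl. What is new is that one of the three groups at this position now takes the read-out to the end of the measurable range, so the position can no longer be described by numbers alone: the limit of > 100000 nM in this assay, at which 1 of the 3 values shown sits.

Still open, going by these compounds, is how the read-out responds on this ring nitrogen to groups of another kind, such as a hydrogen, an ethyl group or a longer chain ending in an amine or a carboxylic acid. Also open, on these data alone, is whether a change elsewhere on the shared core, rather than at this nitrogen, would move the read-out by more than the usual scatter of this kind of measurement.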